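Piperidine to Morpholine in a Series at the Limit

The compounds below may be only part of what the source reports. "The series", "measured", "known", "first", "only" and "open" are said of these compounds alone.

Compound 1 `CC1CCN(C(=O)N2CC(c3nc(-c4cccc(Cl)c4)no3)C2)C1` reaches only the assay limit > 10000 nM in an assay on HEK293 cells for negative allosteric modulation of metabotropic glutamate receptor 5 (Homo sapiens), read by FLIPR; on this read-out lower numbers stand for stronger inhibition and higher numbers for weaker inhibition.
Compound 2 `CC1CCN(C(=O)N2CC(c3nc(-c4cccc(Cl)c4)no3)C2)CC1` likewise reaches only the limit > 10000 nM in this assay.
Compound 3 `COC1CCN(C(=O)N2CC(c3nc(-c4cccc(Cl)c4)no3)C2)CC1` too reaches only the limit > 10000 nM in this assay.

Compound 3 therefore stands where every measured compound stands, at the limit (the limit of > 10000 nM in this assay, at which 3 of the 3 values shown sit), and no number separates it from the others. The three steps between them, a step that the two limits leave unreadable from compound 1 to compound 2, a step that the two limits leave unreadable from compound 1 to compound 3 and a step that the two limits leave unreadable from compound 2 to compound 3, are all hidden by that limit, so none of them can be read for size or direction.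

Compound 4 `CC1CN(C(=O)N2CC(c3nc(-c4cccc(Cl)c4)no3)C2)CC(C)O1` differs from compound 3 by 2,6-dimethylmorpholin-4-yl in place of 4-methoxypiperidin-1-yl on a carbonyl carbon. This change is related to the measured ones only in that it again alters the saturated ring on the carbonyl carbon, and those measured steps were unreadable. The evidence thus gives no ground to expect a step beyond the scatter in this assay in either direction. Compound 4 is accordingly expected to remain at the limit, with an estimate of 15000 nM (range 4000 nM to 60000 nM). The implied step is estimated as a step that the limit leaves unreadable from compound 3 to compound 4.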

Compound 4, half-maximal inhibitory concentration: 990 nM
Estimate against measurement, compound 4: 15-fold (1.18 log units) above, outside the stated range (below it).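

Within the data shown here, compound 4 gives the first readable number in this assay, which shows that the saturated ring on the carbonyl carbon can move this read-out, something the earlier compounds could not show: the limit of > 10000 nM in this assay, at which 3 of the 4 values shown sit. The change to 2,6-dimethylmorpholin-4-yl gives an at least 10-fold lower number from compound 3 to compound 4 (1.00 log units; beyond the scatter) and also an at least 10-fold lower number from compound 2 to compound 4 (1.00 log units; beyond the scatter) and an at least 10-fold lower number from compound 1 to compound 4 (1.00 log units; beyond the scatter). The groups exchanged in the first of these steps hold the same atoms joined differently, so at this position the arrangement of those atoms matters, not their count alone.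

What morpholin-4-yl without its two methyl groups would give on the carbonyl carbon stays open, so the compounds shown do not tell whether the ring oxygen, the methyl groups or both carry the step. On these data alone, whether thiomorpholin-4-yl would keep a readable number also remains open.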